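Cytotoxicity of Four Amides on a Shared Core

The compounds below may be only part of what the source reports. "The series", "measured", "known", "first", "only" and "open" are said of these compounds alone.

Compound 1 `Cc1cc(C)cc(S(=O)(=O)c2c(C(=O)NCc3cccc(F)c3F)[nH]c3ccc(Cl)cc23)c1` gives in an ADME assay on MT4 cells (Homo sapiens) for cytotoxicity, read by MTT assay (on this read-out lower numbers stand for higher toxicity in this test and higher numbers for lower toxicity in this test), the value > 51100 nM, a limit of the test.
Compound 2 `Cc1cc(C)cc(S(=O)(=O)c2c(C(=O)NCC(=O)NC(C)c3ccncc3)[nH]c3ccc(Cl)cc23)c1` gives in this assay the value 47000 nM.
Compound 3 `Cc1cc(C)cc(S(=O)(=O)c2c(C(=O)NCC(=O)NCc3ccccc3F)[nH]c3ccc(Cl)cc23)c1` gives in this assay the value > 47300 nM, again a limit.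

Compound 3 thus stands at a limit, as does one other value; only compound 2 gives a number, and it sits close to both limits. The measured steps are accordingly flat or unreadable: an at least 1.0-fold lower number from compound 1 to compound 2 (0.03 log units; that floor lies within the scatter), while a step that the two limits leave unreadable from compound 1 to compound 3 and a number no lower from compound 2 to compound 3 (the limit leaves the size open) are left open by the limits the limit of > 47300 nM in this assay, at which 1 of the 3 values shown sits, and (the limit of > 51100 nM in this assay, at which 1 of the 3 values shown sits).

Compound 4 `Cc1cc(C)cc(S(=O)(=O)c2c(C(=O)Nc3cc(C#N)ccn3)[nH]c3ccc(Cl)cc23)c1` differs from compound 3 by 4-cyanopyridin-2-yl in place of ((2-fluorobenzyl)carbamoyl)methyl on an amide-type nitrogen. Among the measured compounds shown here, no measured step bears directly on such a change, yet every variation of the amide side so far left the toxicity at or near the limit. Compound 4 is therefore expected to show no step beyond the scatter, an at least 1.0-fold lower number from compound 3 to compound 4 (0.02 log units; that floor lies within the scatter), and its estimate is 45000 nM within 20000 nM to 100000 nM.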

Compound 4, half-maximal cytotoxic concentration: > 53700 nM
Compound 4 ended at the assay's limit; the forecaster's own chance of this, stated with the estimate: 60%; at least 1.1-fold (0.07 log units) between middle value and limit.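

With 4-cyanopyridin-2-yl on the amide-type nitrogen, an aromatic ring takes the place of the chains carried by the earlier compounds, and the result is again a limit of the test: the limit of > 53700 nM in this assay, at which 1 of the 4 values shown sits.

Among the compounds shown here, the only readable comparison is an at least 1.1-fold higher number from compound 2 to compound 4 (0.05 log units; that floor lies within the scatter). The steps to compound 4 from compound 1 and from compound 3 cannot be read.

On these data alone, whether an amine or a carboxylic acid on this nitrogen would give a measurable number in this assay stays open. The limits also leave the order of compound 1, compound 3 and compound 4 unknown.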